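Taking One Methyl Off the Lowest-Reading Antagonist

The compounds below may be only part of what the source reports. "The series", "measured", "known", "first", "only" and "open" are said of these compounds alone.

In a functional assay (aorta) for antagonist activity, with Oryctolagus cuniculus as the target (on this read-out higher numbers stand for weaker inhibition and lower numbers for stronger inhibition), compound 1 `CCCCC1=NC(Cl)=C(C(=O)OCC)C(c2ccccc2)N1Cc1ccc(-c2ccccc2C(=O)O)cc1` gives 1000 nM and compound 2 `CCCCC1=NC(c2ccccc2)=C(C(=O)OCC)C(C)N1Cc1ccc(-c2ccccc2C(=O)O)cc1` gives 630 nM, two values that lie within the usual scatter of each other. Compound 3 `CCCCc1nc(C)c(C(=O)OCC)c(=O)n1Cc1ccc(-c2ccccc2C(=O)O)cc1` stands lowest of the three at 95 nM, beyond the scatter from both of the others, with compound 2 as its nearest neighbour on the numbers.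

Compound 4 `CCCCc1ncc(C(=O)OCC)c(=O)n1Cc1ccc(-c2ccccc2C(=O)O)cc1` has not yet been measured. It differs from compound 3 in one place, with hydrogen in place of methyl on an aromatic carbon. For the measured compounds named here, no pair of measured compounds isolates a single change, so the data offer no direct guide to this swap. With compound 3 at 95 nM the lowest of the three, a modest rise in the number is expected in this assay, of a size near the edge of the scatter. The estimated change is a 1.7-fold higher number from compound 3 to compound 4 (0.23 log units; within the scatter). For compound 4 the expected value is 160 nM, with an estimated range of 55 nM to 450 nM.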

Compound 4, antagonist equilibrium constant: 610 nM
Estimate against measurement, compound 4: 3.8-fold (0.58 log units) below; measured number outside the range, above it.
By their numbers in this assay, from the lowest: compound 3; then compounds 4, 2 and 1 (each within the scatter of the next).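

In this assay, for the compounds shown here, the swap of methyl for hydrogen, on the aromatic carbon next to the ring nitrogen and ortho to the ethoxycarbonyl group, gives a 6.4-fold higher number from compound 3 to compound 4 (0.81 log units; beyond the scatter) and is the first step here that isolates a single change. It shows that this one position, with the loss of just one carbon, moves the read-out by more than the usual scatter, and that methyl goes with the lower number of the pair. Nothing measured here accounts for the size of this step.

Going by these compounds, whether an ethyl group, a methoxy group, an amine or chlorine on this carbon would keep the number as low as methyl does remains open. So does whether a carboxylic acid in place of the neighbouring ethoxycarbonyl group would alter the effect of the same swap.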